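The source may hold more compounds than are shown below. What is called first, only, known or untested is meant among the compounds shown, and "the series" means these compounds.

Four compounds built on a shared core are set against one another in an ADME assay on ECV-304 cells (Homo sapiens) for cytotoxicity, read by MTT assay, with a stated time of 72 h; a higher number here means a weaker inhibitor, a lower number a stronger inhibitor. Compound 1 `COc1ccc(C2=C(c3cc(OC)c(OC)c(OC)c3)C(=O)C(OC(C)=O)C2)cc1F` gives 41 ug/mL in this assay. Compound 2 `COC(=O)c1cc(C2=C(c3cc(OC)c(OC)c(OC)c3)C(=O)CC2O[SiH2]C(C)(C)C)ccc1OC` reaches only > 100 ug/mL in this assay, which is a limit of the assay rather than a number. Compound 3 `COc1ccc(C2=C(c3cc(OC)c(OC)c(OC)c3)C(=O)C(O)C2)cc1NC(=O)c1ccccc1` likewise gives > 100 ug/mL in this assay, again a limit and not a number. So compound 3 stands at the limit of > 100 ug/mL in this assay, at which 2 of the 3 values shown sit, together with compound 2, and only compound 1 shows a measured number.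

Compound 4 `COc1ccc(C2=C(c3cc(OC)c(OC)c(OC)c3)C(=O)C(O)C2)cc1` differs from compound 3 in one place: hydrogen in place of benzamido on an aromatic carbon. Among the compounds with values here, no measured pair of compounds reproduces this change, so the size of the step cannot be read from the data. Because compound 1, which also carries no large group on that ring, gives 41 ug/mL, compound 4 is expected to move back into the measurable range, with an expected step of an at least 2.0-fold lower number from compound 3 to compound 4 (0.30 log units; that floor lies within the scatter). The estimate for compound 4 in this assay is 50 ug/mL, between 15 ug/mL and 100 ug/mL.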

Compound 4, half-maximal inhibitory concentration: < 1 ug/mL
Compound 4 gave a limit, no number; the forecaster's own chance of this, stated with the estimate: 30%; middle value at least 50-fold (1.69 log units) away from the limit.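

In this assay, exchanging benzamido for hydrogen on this aromatic carbon, ortho to a methoxy group, is a large move: an at least 100-fold lower number from compound 3 to compound 4 (2.00 log units; beyond the scatter). Within the data shown here, the earlier compounds offered no step between neighbours, so this is the first sign that this one place on the ring can decide whether a compound sits at one end of the assay's range or the other. Compound 4 stands at a limit of the assay, not at a number, and it is alone there: the limit of < 1 ug/mL in this assay, at which 1 of the 4 values shown sits.

The compounds shown leave open how the effect grows between hydrogen and benzamido, since a small amine or an acetamido group at this place would fall between the two. Compound 1 differs from compound 4 in more than one place, so it cannot settle what a fluorine alone does here.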